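The source may report more compounds than this note shows. Statements on the series, on what has been measured and on what is new or still open speak of the compounds shown alone.

Measured in an in vivo ADME assay on the whole organism (plasma, strain Sprague-Dawley) for pharmacokinetics, with Rattus norvegicus as the target, at a dose of 1 mg/kg by the intravenous route; a higher number here means faster removal of the compound, a lower number slower removal:
- compound 1 `CCOC[C@H]1C[C@@](CC(C)C)(C(=O)O)N(C(=O)c2ccc(C(C)(C)C)c(OC)c2)[C@H]1c1nccs1`: 5 mL/min/kg
- compound 2 `COC[C@H]1C[C@@](CC(C)C)(C(=O)O)N(C(=O)c2ccc(C(C)(C)C)c(OC)c2)[C@H]1c1nccs1`: 5 mL/min/kg
- compound 3 `COC[C@@H]1C[C@@](CC(C)C)(C(=O)O)N(C(=O)c2ccc(C(C)(C)C)c(OC)c2)[C@H]1c1nccs1`: 12 mL/min/kg

Compound 3 has the highest number of the three, at 12 mL/min/kg. Compound 1 and compound 2 show the same value at the digits given, 5 mL/min/kg.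

The next candidate is compound 4 `COc1cc(C(=O)N2[C@@H](c3nccs3)[C@H](CO)C[C@@]2(CC(C)C)C(=O)O)ccc1C(C)(C)C`, which turns the methoxymethyl of compound 3 into hydroxymethyl: hydrogen in place of methyl on an oxygen on a saturated carbon. Hydrogen thus takes the place of methyl on an oxygen on a saturated carbon.

Going by the values given here, two measured steps bear on this. The closer in kind is no change at the digits printed from compound 1 to compound 2 (within the scatter). It also shortens the group on that oxygen, but it leaves an ether in place and was made on the configuration of compound 2, not that of compound 3. The other step, a 2.4-fold higher number from compound 2 to compound 3 (0.38 log units; beyond the scatter), is modest, and the one thing to point to for it is the fact that compounds 2 and 3 differ only in the configuration as drawn. It shows that this series can respond to the configuration at that ring carbon, and compound 4 keeps the configuration of compound 3.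

Among the compounds with values here, no measured compound carries a free hydroxymethyl, so the expectation is loose and rests mainly on the flat result of the ether trimming. No step beyond the scatter is expected, and the estimated change is a 1.2-fold lower number from compound 3 to compound 4 (0.08 log units; within the scatter). In this assay the estimate for compound 4 is 10 mL/min/kg, with an expected range from 4 mL/min/kg to 25 mL/min/kg.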

Compound 4, clearance: 39 mL/min/kg
Compound 4: middle estimate off by 3.9-fold (0.59 log units), on the low side, outside the stated range (above it).
By their numbers in this assay, from the lowest: compounds 1 and 2 (each within the scatter of the next); then compound 3; then compound 4.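

Removing the methyl from the oxygen to leave a free hydroxymethyl behaves differently from shortening the ether in this assay: the change gives a 3.3-fold higher number from compound 3 to compound 4 (0.51 log units; beyond the scatter), whereas hydrogen in place of methyl on a saturated chain carbon bound to an oxygen gives no change at the digits printed from compound 1 to compound 2 (within the scatter). The flat response to trimming the ether therefore does not carry over to removing the methyl on the oxygen, and compound 4, at 39 mL/min/kg, has the highest number of the four compounds. The data shown offer no basis for explaining this step.

From the compounds shown here alone, the two side-chain steps sit on different configurations at the ring carbon, so it remains open whether hydroxymethyl would raise the number to a similar extent on the configuration of compound 2. Also open, going by these compounds, is how this position responds to a group such as an aminomethyl or a carboxylic acid in place of the hydroxymethyl, and whether the higher number stays tied to the free hydroxyl or extends to other groups there.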